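From compound 2 to compound 4: side chain exchange

The compounds below may be only part of what the source reports. "The series", "measured", "known", "first", "only" and "open" are said of these compounds alone.

Values in a functional assay on MDA-MB-231 cells (Homo sapiens) for inhibition, read by sulforhodamine B assay, with a stated time of 72 h; a higher number here means a weaker inhibitor of growth, a lower number a stronger inhibitor of growth
compound 1 `CN1CCN(C(=O)/C=C/c2ccncc2-c2ccc3ccccc3c2)CC1` gives > 10000 nM
compound 2 `CCOC(=O)/C=C/c1ccncc1-c1ccc2ccccc2c1` gives 8090 nM
compound 3 `CCOC(=O)/C=C/c1ccncc1-c1ccc2cc[nH]c2c1` gives 7980 nM

The entry for compound 1 is a limit and not a number. For the measured compounds named here, compound 2 and compound 3 give the only two numbers, and these lie within the scatter of each other, so compound 2 is not set apart from compound 3.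

Compound 4 `CNC(=O)CCc1ccncc1-c1ccc2ccccc2c1` carries 2-(methylcarbamoyl)ethyl in place of 2-(ethoxycarbonyl)ethenyl on an aromatic carbon. Going by the values given here, one measured step bears on this change, and only in part: an at least 1.2-fold lower number from compound 1 to compound 2 (0.09 log units; that floor lies within the scatter) with ethoxy in place of 4-methylpiperazin-1-yl on a carbonyl carbon. On these data alone, its true size stays open. Read in reverse, it gives at most a weak hint of a higher number for a carbonyl carbon without ethoxy.

In this assay the expected change is a 1.2-fold higher number from compound 2 to compound 4 (0.09 log units; within the scatter) and thus no step beyond the scatter. Compound 4 may also report only at the limit of > 10000 nM in this assay, at which 1 of the 3 values shown sits, and not as a number. The estimate for compound 4 is 10000 nM with an expected range from 5000 nM to 20000 nM on present evidence.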

Compound 4, concentration for 50% growth inhibition: 8980 nM
Compound 4: middle estimate off by 1.1-fold (0.05 log units), on the high side, within the range that was stated.
By their numbers in this assay, from the lowest: compounds 3, 2 and 4 (each within the scatter of the next). At a limit, above all of these: compound 1.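

In this assay, 2-(methylcarbamoyl)ethyl in place of 2-(ethoxycarbonyl)ethenyl on the aromatic carbon opposite the ring nitrogen gives a 1.1-fold higher number from compound 2 to compound 4 (0.05 log units; within the scatter), so the exchange cannot be told apart from repeat measurement. The whole side chain changes here, not only the group on the carbonyl carbon: a double bond outside aromatic rings goes, and a hydrogen-bond donor enters, yet the read-out stays within the scatter. Compound 1 remains the only compound reported as a limit and not as a number: the limit of > 10000 nM in this assay, at which 1 of the 4 values shown sits.

The exchange changes the linking chain and its end group together, so the contribution of each stays unresolved. On these data alone, whether a carboxylic acid or an amine at the chain end, or a longer chain, would shift the number beyond the scatter remains open.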